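The compounds below may be only part of what the source reports. "The series", "measured", "known", "first", "only" and "open" are said of these compounds alone.

Compound 1 `O=C(CCCCC(S)CCS)Nc1ccccc1` and compound 2 `O=C(CCCCC(S)CCS)Nc1cccc(Cl)c1` share a core with free thiols. In a functional assay on Bel-7402 cells (Homo sapiens) for inhibition, read by MTT assay, with a stated time of 24 h, tested at 0.1 ug/mL (on this read-out higher numbers stand for more inhibition of growth at the one concentration tested and lower numbers for less inhibition of growth), compound 1 gives 0.85%, and compound 2 gives 3.09%. The change between them, (chloro in place of hydrogen on an aromatic carbon), produced a number 2.2 percentage points higher from compound 1 to compound 2 (within the scatter). Compound 3 `O=C(CCCCC(CCSC(=O)c1ccccc1)SC(=O)c1ccccc1)Nc1ccccc1` carries both thiols as benzoyl thioesters; in this assay compound 3 was reported as "not active" (no number reported). The difference between the two cores is not broken down here. Compound 4 `O=C(CCCCC(CCSC(=O)c1ccccc1)SC(=O)c1ccccc1)Nc1ccccc1Cl` is awaited, and the change chloro in place of hydrogen on an aromatic carbon is the same kind of change as that from compound 1 to compound 2, though the place differs: meta to a large group in the first pair, ortho to a large group in the second. Since the first step stayed within the scatter and compound 3 showed no activity, compound 4 is expected to give about 2%, likely between -6% and 10%.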

Compound 4, percent growth inhibition at one concentration: 5.72%
Compound 4: the middle estimate sits 3.7 percentage points below what was measured, within the range that was stated.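

Among the compounds shown here, compound 3 was reported as "not active" without a number, so no step from compound 3 to compound 4 can be read. No available evidence bears on this result. The compounds shown leave open what the chloro change does on the thioester core.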